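The source may report more compounds than this note shows. Statements on the series, on what has been measured and on what is new or still open speak of the compounds shown alone.

Measured so far:
- compound 1, `O=C1/C(=C/c2ccccc2)CCc2ccccc21`: 7420 nM
- compound 2, `O=C1/C(=C/c2ccc(F)cc2)CCc2ccccc21`: 33400 nM
- compound 3, `O=C1/C(=C/c2ccc(Br)cc2)CCc2ccccc21`: limit, see below

In a functional assay on CCRF-CEM cells (Homo sapiens) for inhibition (a lower number here means a stronger inhibitor, a higher number a weaker inhibitor), compound 1 gives 7420 nM, the lowest of the two numbers shown; the nearest number is that of compound 2, 33400 nM. Compound 3 gives only a limit of the assay, > 500000 nM, and no number. Both substitutions on the pendant aromatic ring raise the number: a 4.5-fold higher number from compound 1 to compound 2 (0.65 log units; beyond the scatter), and an at least 67-fold higher number from compound 1 to compound 3 (1.82 log units; beyond the scatter), with an at least 14-fold higher number from compound 2 to compound 3 (1.17 log units; beyond the scatter) between the two halogens; the last two rest on (the limit of > 500000 nM in this assay, at which 1 of the 3 values shown sits).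

Compound 4, `Cc1cccc(/C=C2\CCc3ccccc3C2=O)c1`, differs from compound 1 by methyl in place of hydrogen on an aromatic carbon. Going by the values given here, no measured step puts a methyl on this ring, and none puts any group at this place; the fluoro and bromo steps both bear on it only as substitutions of the same ring, each moving the number upward, the smaller of them modest. A loss of the modest kind is therefore expected, not one of the bromo kind, and the step is estimated as a 1.6-fold higher number from compound 1 to compound 4 (0.21 log units; within the scatter). Compound 4 is estimated at 12000 nM, within 4000 nM to 40000 nM.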

Compound 4, half-maximal inhibitory concentration: 9410 nM
Estimate against measurement, compound 4: 1.3-fold (0.11 log units) above, and the stated range covers the measured number.
By their numbers in this assay, from the lowest: compounds 1 and 4 (each within the scatter of the next); then compound 2. At a limit, above all of these: compound 3.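

In this assay, going by these compounds alone, methyl in place of hydrogen, meta to a large group, leaves the number within the scatter: a 1.3-fold higher number from compound 1 to compound 4 (0.10 log units; within the scatter) is the first step on this ring of that kind. Against a 4.5-fold higher number from compound 1 to compound 2 (0.65 log units; beyond the scatter) and an at least 67-fold higher number from compound 1 to compound 3 (1.82 log units; beyond the scatter) as steps beyond the scatter, the second resting on a limit of the assay, compound 4 goes against any reading that every substitution on this ring raises the number. Nothing shown gives a measured cause for this step.

The compounds shown do not separate the group from the place, since methyl has no counterpart at the place of fluoro and bromo, and neither halogen has one at the place of methyl. Open too, as far as these compounds go, is how this place takes a larger or different group, such as an ethyl chain, a methoxy group or an amine.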